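A few compounds are considered here, and "the series" means these few. Any claim that something is new, unique, unknown or untested is made for them only; others in the source may bear on it.

Compound 1, `Cc1nc(N)sc1CCCN/C(N)=N/C(=O)NC(C)c1ccc(Br)cc1`, was tested in a functional assay on Right cardiac atrium for agonist activity at histamine H2 receptor (Cavia porcellus), with a stated time of 30 min, in the presence of a further agent that is not named here (on this read-out higher numbers stand for an effect only at larger amounts of compound and lower numbers for an effect already at smaller amounts), where compound 1 gives 55 nM. Two close relatives were run in the same test: compound 2, `Cc1nc(N)sc1CCCN/C(N)=N/C(=S)N[C@H](C)c1ccccc1`, gives 89.1 nM, and compound 3, `Cc1nc(N)sc1CCCN/C(N)=N/C(=S)N[C@@H](C)c1ccccc1`, gives 224 nM. Compound 1 and compound 2 sit within the scatter of each other, while compound 3 stands beyond the scatter from compound 1. Going by the values given here, the only measured step between neighbours is a 2.5-fold higher number from compound 2 to compound 3 (0.40 log units; beyond the scatter), and it rests on (the fact that compounds 2 and 3 differ only in the configuration as drawn); the aromatic ring itself is left untouched in that step.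

The next compound, compound 4, `Cc1nc(N)sc1CCCN/C(N)=N/C(=O)NC(C)c1ccco1`, differs from compound 1 in one place: furan-2-yl in place of 4-bromophenyl on a saturated chain carbon bound to an amide-type nitrogen and a saturated chain carbon. Everything else in compound 1 is kept. Among the compounds with values here, the single measured step, a change of configuration at a saturated chain carbon, does not speak to a swap of one aromatic ring for another, and no measured pair shows what the furan-2-yl brings in place of the 4-bromophenyl. In this assay compound 4 is therefore expected to land near compound 1, with the change estimated as a 1.6-fold higher number from compound 1 to compound 4 (0.21 log units; within the scatter). The estimate for compound 4 is 90 nM, expected to fall between 35 nM and 250 nM.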

Compound 4, half-maximal effective concentration: 9.77 nM
Estimate against measurement, compound 4: 9.2-fold (0.96 log units) above; measured number outside the range, below it.
By their numbers in this assay, from the lowest: compound 4; then compounds 1 and 2 (each within the scatter of the next); then compound 3.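

In this assay, the place on a saturated chain carbon bound to an amide-type nitrogen and a saturated chain carbon proves open to a change of the aromatic ring itself: furan-2-yl in place of 4-bromophenyl gives a 5.6-fold lower number from compound 1 to compound 4 (0.75 log units; beyond the scatter) and so moves the number to the low end of the series. Going by these compounds alone, until now, the only step read at this kind of carbon was a change of configuration, so the earlier compounds said nothing about the ring, whereas here a five-membered ring with 5 heavy atoms and one hetero atom does better than a six-membered carbon ring with 7 heavy atoms. What lies behind this gain cannot be said, as the one known fact concerns configuration and does not bear on a swap of rings.

Within the data shown here, the single swap removes the bromine, shrinks the ring and brings in the ring oxygen all at once, and how much each of these contributes stays open; a plain phenyl or a thiophen-2-yl ring at this place would help to separate them. Also open, on these data alone, is whether the two configurations at this carbon differ when it carries furan-2-yl, as compound 4 is drawn without a stated configuration.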